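This account rests on a few compounds, and the source may have more. Where it says the series, first, only, none or still open, it means among the compounds named here.

Measured so far in a functional assay on DLD-1 cells (Homo sapiens) for cytotoxicity, with a stated time of 48 h (on this read-out higher numbers stand for weaker inhibition and lower numbers for stronger inhibition), are three compounds:

Compound 1 `CC(C)COc1ccc2oc(/C=C/[S+](C)[O-])cc(=O)c2c1` gives 5000 nM
Compound 2 `C[S+]([O-])/C=C/c1cc(=O)c2cc(F)ccc2o1` gives 7000 nM
Compound 3 `C[S+]([O-])/C=C/c1cc(=O)c2cc(Cl)ccc2o1` gives 6500 nM

Compound 3 does not stand apart from the other two. Its number lies within the usual scatter of both neighbours, as the steps (a 1.3-fold higher number from compound 1 to compound 3 (0.11 log units; within the scatter)) and (a 1.1-fold lower number from compound 2 to compound 3 (0.03 log units; within the scatter)) show.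

The next compound, not yet measured, is compound 4 `CC(C)Oc1ccc2oc(/C=C/[S+](C)[O-])cc(=O)c2c1` in which isopropoxy replaces chloro on an aromatic carbon (isopropoxy in place of chloro on an aromatic carbon). The closest guide is compound 1, which carries isobutoxy, another group joined through oxygen, in the same place. Exchanging that group for chloro gave only a small shift (a 1.3-fold higher number from compound 1 to compound 3 (0.11 log units; within the scatter)), and exchanging it for fluoro did much the same (a 1.4-fold higher number from compound 1 to compound 2 (0.15 log units; within the scatter)). Both changes stayed within the scatter, so none of the three measured compounds separates from the others. Among the compounds with values here, no isopropoxy compound has been measured yet, so this comparison is the only evidence available.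

No step beyond the scatter is therefore expected, only a slight drift towards the value of compound 1. The expected step in this assay is small (a 1.2-fold lower number from compound 3 to compound 4 (0.07 log units; within the scatter)) and remains an estimate. Compound 4 is estimated at 5500 nM with an expected range from 3000 nM to 9500 nM on this read-out.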

Compound 4, half-maximal inhibitory concentration: 8000 nM
Estimate against measurement, compound 4: 1.5-fold (0.16 log units) below; the range from low to high includes it.
By their numbers in this assay, from the lowest: compounds 1, 3, 2 and 4 (each within the scatter of the next).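

In this assay, this position has now carried four groups (fluoro, chloro, isobutoxy and isopropoxy), and the new compound does not separate from any of the others. Putting isopropoxy in place of chloro (a 1.2-fold higher number from compound 3 to compound 4 (0.09 log units; within the scatter)) or in place of fluoro (a 1.1-fold higher number from compound 2 to compound 4 (0.06 log units; within the scatter)) adds three heavy atoms overall in the first case and a hydrogen-bond acceptor in both, yet neither step leaves the scatter. Within the data shown here, the one change confined to the chain on the oxygen, isopropyl in place of isobutyl (a 1.6-fold higher number from compound 1 to compound 4 (0.20 log units; within the scatter)), also stays within the scatter, so these two groups joined through oxygen cannot be told apart here, just as neither can be told apart from fluoro or chloro.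

Still open, as far as these compounds go, is whether a group of another kind at this position, such as an amine, a carboxylic acid or a longer chain on the oxygen, would give a number beyond the scatter in this assay, or whether changes elsewhere on the shared core would do so. No independent measurement is available to explain how these four numbers relate to the structures.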